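Amide substituent variation, compound 2 to compound 4

A few compounds are considered here, and "the series" means these few. Any claim that something is new, unique, unknown or untested is made for them only; others in the source may bear on it.

Values in an assay on microsomes from liver for inhibition of 3-hydroxy-3-methylglutaryl-coenzyme A reductase (Rattus norvegicus); a lower number here means a stronger inhibitor, a higher number a weaker inhibitor:
Compound 1 `Cc1ccc(CNC(=O)c2nn(-c3ccc(F)cc3)c(CC[C@@H](O)C[C@@H](O)CC(=O)O)c2C(C)C)cc1`: 2.5 nM
Compound 2 `CC(C)c1c(C(=O)NCc2cccc(F)c2F)nn(-c2ccc(F)cc2)c1OC[C@@H](O)C[C@@H](O)CC(=O)O`: 2 nM
Compound 3 `COc1ccc(CNC(=O)c2nn(-c3ccc(F)cc3)c(OC[C@@H](O)C[C@@H](O)CC(=O)O)c2C(C)C)cc1`: 12 nM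

Compound 2 gives the lowest number of the three. Compound 1 lies within the scatter of it, so no order can be read between these two. Among the compounds with values here, compound 3 lies beyond the scatter, a 6.0-fold higher number from compound 2 to compound 3 (0.78 log units; beyond the scatter), the only step with a single change among the measured compounds.

Compound 4 `COc1cccc(CNC(=O)c2nn(-c3ccc(F)cc3)c(OC[C@@H](O)C[C@@H](O)CC(=O)O)c2C(C)C)c1` differs from compound 2 in one place: 3-methoxyphenyl in place of 2,3-difluorophenyl on a saturated chain carbon bound to an amide-type nitrogen. The step from compound 2 to compound 3, with 4-methoxyphenyl in place of 2,3-difluorophenyl at the same place, bears on it directly and was modest but beyond the scatter. A rise of similar or somewhat smaller size is therefore expected in this assay, a 3.5-fold higher number from compound 2 to compound 4 (0.54 log units; beyond the scatter). Compound 4 is estimated at 7 nM, with a range of 2.5 nM to 20 nM.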

Compound 4, half-maximal inhibitory concentration: 16 nM
Compound 4: middle estimate off by 2.3-fold (0.36 log units), on the low side, within the range that was stated.
By their numbers in this assay, from the lowest: compounds 2 and 1 (each within the scatter of the next); then compounds 3 and 4 (each within the scatter of the next).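

In this assay, 3-methoxyphenyl in place of 2,3-difluorophenyl also gives a rise beyond the scatter (an 8.0-fold higher number from compound 2 to compound 4 (0.90 log units; beyond the scatter)), so the rise seen with 4-methoxyphenyl is not confined to that one methoxy isomer. The two methoxy isomers cannot be told apart (a 1.3-fold higher number from compound 3 to compound 4 (0.12 log units; within the scatter)). No measurement at hand accounts for the rise from 2,3-difluorophenyl to either methoxyphenyl. Open, as far as these compounds go, is whether unsubstituted phenyl or 3-fluorophenyl on this carbon keeps the low number of compound 2 (2 nM). Also open, from the compounds shown here alone, is whether the step follows from gaining methoxy or from losing fluorine.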